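This account rests on a few compounds, and the source may have more. Where it says the series, first, only, none or still open, it means among the compounds named here.

In a functional assay on HCT-116 cells (Homo sapiens) for antiproliferative activity, read by MTT assay, with a stated time of 48 h (a higher number here means a weaker inhibitor, a lower number a stronger inhibitor), compound 2 `COc1ccc(-n2cc(COc3ccc(/C=C/C(C)=O)cc3OC)nn2)cc1` gives 21300 nM, compound 3 `COc1cccc(-n2cc(COc3ccc(/C=C/C(C)=O)cc3OC)nn2)c1` gives 29600 nM, and compound 1 `COc1cc(/C=C/C(C)=O)ccc1OCc1cn(-c2c(F)cccc2F)nn1` gives 37700 nM. Compound 2 therefore stands within the scatter of both neighbours. Compound 4 `CCOC(=O)c1ccc(-n2cc(COc3ccc(/C=C/C(C)=O)cc3OC)nn2)cc1` carries ethoxycarbonyl in place of methoxy on an aromatic carbon of compound 2: ethoxycarbonyl in place of methoxy on an aromatic carbon. Among the measured compounds shown here, three measured steps bear on this change, each exchanging the group on the aromatic nitrogen: a 1.8-fold lower number from compound 1 to compound 2 (0.25 log units; within the scatter), a 1.3-fold lower number from compound 1 to compound 3 (0.11 log units; within the scatter) and a 1.4-fold higher number from compound 2 to compound 3 (0.14 log units; within the scatter). None of them introduces ethoxycarbonyl, and none leaves the scatter, so they indicate no direction. No step beyond the scatter is expected in this assay, and the estimated change is a 1.2-fold higher number from compound 2 to compound 4 (0.07 log units; within the scatter). For compound 4 the expected value is 25000 nM, with an estimated range of 11000 nM to 50000 nM.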

Compound 4, half-maximal inhibitory concentration: 78900 nM
Beside the measured number, compound 4's estimate is 3.2-fold (0.50 log units) below it, and the stated range ends below it.
By their numbers in this assay, from the lowest: compounds 2, 3 and 1 (each within the scatter of the next); then compound 4.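

In this assay, ethoxycarbonyl in place of methoxy gives the only step shown that lies beyond the scatter: a 3.7-fold higher number from compound 2 to compound 4 (0.57 log units; beyond the scatter). The earlier steps shown here, all exchanges of the group on the aromatic nitrogen, stayed within the scatter, so this aromatic carbon, para to a large group, is not indifferent to the exchange of methoxy for ethoxycarbonyl. Nothing available explains this step. The compounds shown leave open whether a carboxylic acid or an amine on this carbon would stand nearer compound 2 or compound 4.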